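The compounds below may be only part of what the source reports. "The series", "measured", "known", "first", "only" and "open" are said of these compounds alone.

Measured so far in an ADME assay on HEL cells (Homo sapiens) for cytotoxicity, with a stated time of 3 days; on this read-out higher numbers stand for lower toxicity in this test and lower numbers for higher toxicity in this test:
compound 1, `Cc1cc(-c2ccc(O)cc2)cn2c(CSCCc3ccccc3)cnc12`: >= 100 ug/mL
compound 2, `Cc1cc(I)c2ncc(CSCCc3ccccc3)n2c1`: >= 4 ug/mL

Of the compounds shown here, two have been tested in this assay, and the question is what a third, compound 3 with structure `Cc1cc(-c2ccc(C#N)cc2)cn2c(CSCCc3ccccc3)cnc12`, will show. Compound 1 is the point of departure. In this assay compound 1 gives >= 100 ug/mL, which is a limit of the test rather than a number; it stands at the limit of >= 100 ug/mL in this assay, at which 1 of the 2 values shown sits. Compound 2 also reaches only a limit, >= 4 ug/mL, namely (the limit of >= 4 ug/mL in this assay, at which 1 of the 2 values shown sits). Among the compounds with values here, the two measured compounds differ from each other in more than one place, so no single step between them is counted, and neither of them yields a number to compare.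

Compound 3 arises from compound 1 by one change: cyano in place of hydroxy on an aromatic carbon. Read one bond further out, a 4-hydroxyphenyl becomes a 4-cyanophenyl. Within the data shown here, no measured step shows how such a swap moves this read-out, so the expectation rests on compound 1 alone. For compound 3 the expected step is a number no higher from compound 1 to compound 3 (the limit leaves the size open), nothing beyond the scatter. Compound 3 is therefore estimated at 100 ug/mL, between 50 ug/mL and 200 ug/mL, and most likely it too will be reported only as a limit.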

Compound 3, minimum cytotoxic concentration: >= 20 ug/mL
Compound 3: a limit, no number; the forecaster's own chance of this, stated with the estimate: 70%; the middle value does not contradict the limit.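

In this assay compound 1 gives >= 100 ug/mL, which is a limit and not a number. Compound 3 gives >= 20 ug/mL, which is also a limit. No step can be read between compound 1 and compound 3. The compounds shown leave open how far, and in which direction, cyano in place of hydroxy moves the minimum cytotoxic concentration.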